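Side-chain swap on the shared core: compound 3 to compound 4

The source may report more compounds than this note shows. Statements on the series, on what has been measured and on what is new or still open speak of the compounds shown alone.

Measured so far:
Compound 1 `COCC(COC)Nc1nc(C)nc2c1nnn2-c1ccc(C(C)C)cc1Br`: 10.3 nM
Compound 2 `CCN(c1nc(C)nc2c1nnn2-c1ccc(C(C)C)cc1Br)C(COC)COC`: 123 nM
Compound 3 `CCCC(CN(C)C)Nc1nc(C)nc2c1nnn2-c1ccc(C(C)C)cc1Br`: 38.7 nM

Among these three numbers from an in vitro assay on 293-EBNA cells for binding affinity to corticotropin-releasing factor receptor 1 (Homo sapiens) (on this read-out higher numbers stand for weaker inhibition and lower numbers for stronger inhibition), compound 3 has the second highest; compound 1 sits below it, a step of a 3.8-fold higher number from compound 1 to compound 3 (0.57 log units; beyond the scatter), while compound 2 sits above it, a 3.2-fold lower number from compound 2 to compound 3 (0.50 log units; beyond the scatter). Compound 4 `CCCCC(CC)Nc1nc(C)nc2c1nnn2-c1ccc(C(C)C)cc1Br` differs from compound 3 in one place: a group of 7 heavy atoms (7 carbon; no ring) in place of a group of 8 heavy atoms (7 carbon, 1 nitrogen; no ring), on a nitrogen on an aromatic ring. The step that bears on it most is a 3.8-fold higher number from compound 1 to compound 3 (0.57 log units; beyond the scatter), which shows that exchanging the whole chain on this nitrogen moves the number by a modest amount; the large step of a 12-fold higher number from compound 1 to compound 2 (1.08 log units; beyond the scatter) concerns substitution on the nitrogen itself and is less relevant. A modest step is therefore expected, toward a lower number. For compound 4 the estimate is 15 nM, with a range from 4 nM to 60 nM, which means an expected step of a 2.6-fold lower number from compound 3 to compound 4 (0.41 log units; beyond the scatter).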

Compound 4, inhibition constant: 3.1 nM
Estimate against measurement, compound 4: 4.8-fold (0.68 log units) above, and the stated range ends above it.
By their numbers in this assay, from the lowest: compound 4; then compound 1; then compound 3; then compound 2.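

In this assay, the all-carbon 1-ethylpentyl chain on this nitrogen gives the lowest number of the four compounds, with a large gain over the amine-bearing chain (a 12-fold lower number from compound 3 to compound 4 (1.10 log units; beyond the scatter)) and a larger one over the ethyl-substituted nitrogen with its ether chain (a 40-fold lower number from compound 2 to compound 4 (1.60 log units; beyond the scatter)). The modest step from the ether chain (a 3.3-fold lower number from compound 1 to compound 4 (0.52 log units; beyond the scatter)) shows that neither oxygen nor nitrogen in this chain is needed for a low number. No measurement here explains these steps. From the compounds shown here alone, whether a longer chain or a cyclopentyl group would match 1-ethylpentyl remains open. So does the effect of ethyl on the nitrogen of compound 4.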